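The source may hold more compounds than are shown below. What is called first, only, known or untested is meant among the compounds shown, and "the series" means these compounds.

Three compounds share one core. Compound 1 `CC(=O)c1cc(CO)c(OCCCCCCC#N)cc1O`, compound 2 `C=CCc1cc(C(C)=O)c(O)cc1OCC#N` and compound 3 `CCc1cc(C(C)=O)c(O)cc1OCCCCCCC(C)(C)C#N` were all tested in an assay on isolated protein for binding affinity to leukotriene B4 receptor 1 (Homo sapiens), tested at 1 uM; on this read-out higher numbers stand for more inhibition at the one concentration tested (going by the name of the read-out) and lower numbers for less inhibition. There compound 1 gives 8%, compound 2 gives 2% and compound 3 gives 30%. Compound 3 stands highest of the three: its gap to compound 1, the nearest, and to compound 2, the furthest, both lie beyond the usual scatter. Compound 4 `CCc1cc(C(C)=O)c(O)cc1OCCCCCCC(=O)O` has not yet been measured in this assay. It differs from compound 3 in one place: carboxy in place of 1-cyano-1-methylethyl on a saturated chain carbon, six bonds along the chain from an oxygen on an aromatic ring. For the measured compounds named here, no measured pair shows this change, so the expectation rests on compound 3 alone. A modest upward step is expected, a number 15 percentage points higher from compound 3 to compound 4 (beyond the scatter), though a flat result would not surprise. Compound 4 is estimated to give 45%, between 15% and 75%.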

Compound 4, a percentage reported as inhibition, at one concentration (the size of the read-out at that concentration, not a potency): 38%
Beside the measured number, compound 4's estimate is 7 percentage points above it; low and high end bracket the measured number.
By their numbers in this assay, from the lowest: compounds 2 and 1 (each within the scatter of the next); then compounds 3 and 4 (each within the scatter of the next).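

In this assay, carboxy in place of 1-cyano-1-methylethyl gives a number 8 percentage points higher from compound 3 to compound 4 (within the scatter), so the two groups cannot be told apart at this place on the saturated chain. For the compounds shown here, this is the first sign that the end of the chain can carry a hydrogen-bond donor without a change beyond the scatter. No supporting data explain why the two groups read alike. Still open, on these data alone, is whether a methyl ester, a primary amide, or a shorter or longer chain ending in carboxy would read the same.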